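Compound 3 after two limits in PBMC cytotoxicity

The compounds below may be only part of what the source reports. "The series", "measured", "known", "first", "only" and "open" are said of these compounds alone.

Measured values in an ADME assay on PBMC cells (Homo sapiens) for cytotoxicity, with a stated time of 5 days (a lower number here means a stronger inhibitor, a higher number a weaker inhibitor), are as follows.
- Compound 1 `C=CCNc1nc(N)nc2c1ncn2[C@H]1C[C@H](N=[N+]=[N-])[C@@H](CO)O1` gives > 100000 nM as a limit of the assay
- Compound 2 `CC(CO)Nc1nc(N)nc2c1ncn2[C@H]1C[C@H](N=[N+]=[N-])[C@@H](CO)O1` gives > 100000 nM as a limit of the assay

Among the compounds with values here, compound 2 stands at > 100000 nM as a limit and not a number, and the only other value shown is a limit too.

The next compound is compound 3 `C=CCN(C)c1nc(N)nc2c1ncn2[C@H]1C[C@H](N=[N+]=[N-])[C@@H](CO)O1` with allyl(methyl)amino in place of (1-(hydroxymethyl)ethyl)amino on an aromatic carbon. The counted difference is allyl(methyl)amino in place of (1-(hydroxymethyl)ethyl)amino on an aromatic carbon and the rest of the structure stays the same.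

Within the data shown here, one measured step bears on this change, namely a step that the two limits leave unreadable from compound 1 to compound 2 in which the same kind of exchange was made between allyl and 1-(hydroxymethyl)ethyl on a nitrogen. Among the measured compounds shown here, its size cannot be read because of the limit of > 100000 nM in this assay, at which 2 of the 2 values shown sit, and no step of known size remains as a guide.

No readable step is therefore expected in this assay and any number that did appear could only lie toward the stronger side. The expected change is an at least 1.1-fold lower number from compound 2 to compound 3 (0.04 log units; that floor lies within the scatter) and this remains an estimate.

For compound 3 the estimated value is 90000 nM with an expected range from 30000 nM to 100000 nM in this assay.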

Compound 3, half-maximal inhibitory concentration: > 100000 nM
Compound 3 gave a limit, no number (the forecaster's own chance of this, stated with the estimate: 75%); at least 1.1-fold (0.04 log units) between middle value and limit.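

In this assay compound 3 gives > 100000 nM as a limit of the assay and not a number. Within the data shown here, no step among compound 1, compound 2 and compound 3 can therefore be read: the limit of > 100000 nM in this assay, at which 3 of the 3 values shown sit. The compounds shown leave open whether the exchanged groups on the shared core differ at all in this read-out.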